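The compounds below may be only part of what the source reports. "The series", "measured", "known", "first", "only" and "open" are said of these compounds alone.

Compound 1 `c1ccc(/N=c2\ssnc2-c2ccccc2)cc1` and compound 2 `O=[N+]([O-])c1ccc(-c2nss/c2=N\c2ccccc2)cc1` share one core and differ by a nitro on an aromatic carbon. In a functional assay on MDA-MB-231 cells (Homo sapiens) for antiproliferative activity, read by MTT assay, with a stated time of 72 h, tested at 10 uM (a lower number here means less inhibition, a higher number more inhibition at the concentration tested (going by the name of the read-out)), compound 1 gives 0%, and compound 2 gives 0%, so compound 2 stands level with compound 1 at the digits recorded. For the measured compounds named here, the one measured step, no change at the digits printed from compound 1 to compound 2 (within the scatter), shows that nitro in place of hydrogen brings no change within the scatter. Compound 3 `Fc1ccc(-c2nss/c2=N\c2ccccc2)cc1` differs from compound 2 by the change (fluoro in place of nitro on an aromatic carbon). Going by the values given here, only the step from compound 1 to compound 2 bears on this exchange, and it was flat; with both measured compounds showing no inhibition, nothing indicates that the group on this aromatic carbon moves the read-out. The step to compound 3 is therefore expected to be no change at the digits printed from compound 2 to compound 3 (within the scatter), no change beyond the scatter. Compound 3 is accordingly estimated at 0%, in the range 0% to 12%.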

Compound 3, a percentage reported as inhibition, at one concentration (the size of the read-out at that concentration, not a potency): 0%
For compound 3 middle estimate and measured number coincide at the digits printed; the measured number falls inside the stated range.
By their numbers in this assay, from the lowest: compounds 1, 2 and 3 (each within the scatter of the next).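

Fluoro now joins hydrogen and nitro on this aromatic carbon, and the exchange of nitro for fluoro is flat (no change at the digits printed from compound 2 to compound 3 (within the scatter)) in this assay. The direct comparison with the unsubstituted compound is flat as well (no change at the digits printed from compound 1 to compound 3 (within the scatter)), so all three pairs in the set now lie within the scatter. The flat reading therefore holds for nitro, with three heavy atoms and two hydrogen-bond acceptors, and for fluoro, with one heavy atom and none; no data bear on the reason for this result.

Whether any group at this position can produce inhibition stays open, as an amine, a carboxylic acid or a longer chain lies outside the compounds shown. As far as these compounds go, the effect of changes elsewhere on the shared core also remains open.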